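A few compounds are considered here, and "the series" means these few. Any claim that something is new, unique, unknown or untested is made for them only; others in the source may bear on it.

Measured compounds:
Compound 1 `CN1CCCc2ccc(NC(=O)c3ccc(-c4ccccc4)cc3)cc21` gives 7.5 in a functional assay for antagonist activity at transient receptor potential cation channel subfamily V member 1 (Homo sapiens), read by FLIPR and calcium flux; on this read-out higher numbers stand for higher potency (the scale is a negative logarithm) and lower numbers for lower potency.
Compound 2 `CC(=O)c1cccc(-c2ccc(C(=O)Nc3ccc4c(c3)N(C)CCC4)cc2)c1` gives 7 in this assay.

For the measured compounds named here, compound 2 stands lowest of the two numbers in this assay; the only measured neighbour is compound 1, and the single measured step, a number 0.50 log units lower from compound 1 to compound 2 (beyond the scatter), separates them. Compound 3 `CN1CCCc2ccc(NC(=O)c3ccc(-c4cccs4)cc3)cc21` is not yet measured. Compound 3 differs from compound 2 in one place: thiophen-2-yl in place of 3-acetylphenyl on an aromatic carbon.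

The measured step bears on this change only in part. From compound 1 to compound 2 the acetyl entering the terminal aryl lowered the number modestly, so removing the acetyl group along with that ring could plausibly recover part of what was lost. Going by the values given here, the swap of a six-membered carbon ring for thiophen-2-yl has no measured counterpart here, so its contribution is unknown. Compound 3 is therefore expected to move upward from compound 2 by about a number 0.30 log units higher from compound 2 to compound 3 (within the scatter), roughly toward the value of compound 1. The estimate for compound 3 in this assay is 7.3, expected to fall between 6.7 and 7.9.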

Compound 3, negative logarithm of the antagonist equilibrium constant: 7.6
Estimate against measurement, compound 3: 0.30 log units below, within the range that was stated.
By their numbers in this assay, from the lowest: compound 2; then compounds 1 and 3 (each within the scatter of the next).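

In this assay, the aromatic carbon para to a large group accepts a five-membered aromatic ring as readily as a six-membered one: thiophen-2-yl in place of phenyl gives a number 0.10 log units higher from compound 1 to compound 3 (within the scatter), so ring size at this position, across these two groups, produces no difference that can be told from the scatter. Thiophen-2-yl in place of 3-acetylphenyl gives a number 0.60 log units higher from compound 2 to compound 3 (beyond the scatter), and read with a number 0.50 log units lower from compound 1 to compound 2 (beyond the scatter), this leaves compound 2, the only one of the three carrying an acetyl, standing apart, while the two compounds with an unsubstituted terminal ring stand together. Nothing on hand accounts for this pattern.

As far as these compounds go, whether an acetyl on the thiophene ring would carry the same cost as it does on the phenyl ring remains open, since the terminal ring bears a substituent only in compound 2. Also open, from the compounds shown here alone, is how far this position accepts other groups, such as a furan ring, a pyridine ring, a carboxylic acid or a short chain ending in an amine.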